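From Piperidin-1-yl to Morpholin-4-yl on the Carbonyl Carbon

The source may hold more compounds than are shown below. What is called first, only, known or untested is meant among the compounds shown, and "the series" means these compounds.

compound 1 `CC(C)CCNC(=O)c1ccc(C#Cc2ccccc2)nc1`: 510 nM
compound 2 `CC1CCC(NC(=O)c2ccc(C#Cc3ccccc3)nc2)CC1`: 1200 nM
compound 3 `O=C(c1ccc(C#Cc2ccccc2)nc1)N1CCCCC1`: 280 nM

All three share one core and differ only in the group attached to the carbonyl carbon. Among the measured compounds shown here, in a functional assay on BHK cells for positive allosteric modulation of metabotropic glutamate receptor 5 (Homo sapiens), read by FLIPR and calcium flux (on this read-out higher numbers stand for an effect only at larger amounts of compound and lower numbers for an effect already at smaller amounts), compound 3 shows the smallest number of the three, yet the step of a 1.8-fold lower number from compound 1 to compound 3 (0.26 log units; within the scatter) stays within the scatter, so compound 1 and compound 3 cannot be told apart on these numbers; only the step of a 4.3-fold lower number from compound 2 to compound 3 (0.63 log units; beyond the scatter) is beyond it, and the step of a 2.4-fold higher number from compound 1 to compound 2 (0.37 log units; beyond the scatter) is of similar modest size.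

Compound 4 `O=C(c1ccc(C#Cc2ccccc2)nc1)N1CCOCC1` carries morpholin-4-yl in place of piperidin-1-yl on a carbonyl carbon. For the measured compounds named here, every measured step here is a change of the group on the carbonyl carbon, and none of them moved the numbers by more than a modest amount; none of them, however, exchanged a ring carbon for an oxygen, so the data give no direct precedent for that swap. The most reasonable expectation is a step of a 1.6-fold higher number from compound 3 to compound 4 (0.21 log units; within the scatter), small and not clearly beyond the scatter, with the wider range allowing for a somewhat higher number. Compound 4 is therefore estimated to give 450 nM in this assay, with a range from 200 nM to 1100 nM.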

Compound 4, half-maximal effective concentration: 990 nM
Beside the measured number, compound 4's estimate is 2.2-fold (0.34 log units) below it, and the stated range covers the measured number.
By their numbers in this assay, from the lowest: compounds 3, 1, 4 and 2 (each within the scatter of the next, the first and the last beyond it).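

In this assay, exchanging one ring carbon of piperidin-1-yl for the oxygen of morpholin-4-yl gives a 3.5-fold higher number from compound 3 to compound 4 (0.55 log units; beyond the scatter) and is a modest step beyond the scatter, so the group on the carbonyl carbon responds to a single atom within a six-membered ring, not only to the larger exchanges of group seen earlier. The steps of a 1.9-fold higher number from compound 1 to compound 4 (0.29 log units; within the scatter) and a 1.2-fold lower number from compound 2 to compound 4 (0.08 log units; within the scatter) both stay within the scatter, so compound 4 cannot be told apart from compound 1 or compound 2, and this one swap is enough to remove the clear gap that compound 3 has from compound 2. Morpholin-4-yl brings a hydrogen-bond acceptor that piperidin-1-yl lacks, but nothing available here connects that count, or anything else, to the change in the numbers.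

The compounds shown leave open whether the oxygen itself matters or whether any replacement of that ring carbon would give a similar step. A piperazin-1-yl group, with an amine nitrogen where morpholin-4-yl has its oxygen, or a thiomorpholin-4-yl group, with sulfur there, would test this directly on the same carbonyl carbon.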